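Swapping the Basic Amine on a Urea-Linked Core

The source may hold more compounds than are shown below. What is called first, only, known or untested is meant among the compounds shown, and "the series" means these compounds.

Of the compounds shown here, three built on one shared core have been measured in a functional assay on A-431 cells (Homo sapiens) for antiproliferative activity, read by MTT assay, with a stated time of 72 h; on this read-out higher numbers stand for weaker inhibition and lower numbers for stronger inhibition. Compound 1 `COc1ccc(Nc2ncnc3ccc(NC(=O)Nc4ccc(CN5CCN(C)CC5)cc4)cc23)cc1Cl` gives 2010 nM. Compound 2 `CN1CCN(Cc2ccc(NC(=O)Nc3ccc4ncnc(Nc5cccc(C(F)(F)F)c5)c4c3)cc2)CC1` gives 2410 nM, and compound 3 `COC(=O)c1cccc(Nc2ncnc3ccc(NC(=O)Nc4ccc(CN5CCN(C)CC5)cc4)cc23)c1` gives 5630 nM. Among these three numbers compound 2 stands second highest: the gap a 1.2-fold higher number from compound 1 to compound 2 (0.08 log units; within the scatter) lies within the scatter, whereas a 2.3-fold higher number from compound 2 to compound 3 (0.37 log units; beyond the scatter) and a 2.8-fold higher number from compound 1 to compound 3 (0.45 log units; beyond the scatter) are modest steps beyond it.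

Compound 4 `CCN(CC)Cc1ccc(NC(=O)Nc2ccc3ncnc(Nc4cccc(C(F)(F)F)c4)c3c2)cc1` differs from compound 2 in a single place: diethylamino in place of 4-methylpiperazin-1-yl on a saturated chain carbon bound to an aromatic carbon. Every measured step among the three known compounds concerns a different part of the molecule, namely the group attached to the nitrogen on the aromatic ring, and even the largest of them, a 2.8-fold higher number from compound 1 to compound 3 (0.45 log units; beyond the scatter), was only modest. Going by the values given here, no measured pair tests an exchange of the group on the saturated chain carbon, so nothing in these numbers points to a shift in either direction. The expected change is therefore a 1.0-fold lower number from compound 2 to compound 4 (0.00 log units; within the scatter), a step that stays within the scatter, with a wide range to reflect the absence of any direct precedent. Compound 4 is thus expected to give 2400 nM, with a range from 900 nM to 6500 nM.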

Compound 4, half-maximal inhibitory concentration: 3980 nM
Compound 4: middle estimate off by 1.7-fold (0.22 log units), on the low side; low and high end bracket the measured number.
By their numbers in this assay, from the lowest: compounds 1, 2, 4 and 3 (each within the scatter of the next, the first and the last beyond it).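

Going by these compounds alone, the exchange of 4-methylpiperazin-1-yl for diethylamino is the first measured change on the saturated chain carbon bound to an aromatic carbon, and in this assay it reads a 1.7-fold higher number from compound 2 to compound 4 (0.22 log units; within the scatter) in the number for antiproliferative activity. The opening of the ring therefore leaves the result indistinguishable from that of the parent compound, so in this pair the six-membered ring and its second nitrogen are not needed to stay in the same range of numbers. This holds for one pair only, both members carrying the 3-(trifluoromethyl)phenyl group on the other side of the shared core, and no measurement on hand offers a reason for the size of the step.

Still open, going by these compounds, is whether a smaller amine such as dimethylamino, a ring with oxygen in place of the second nitrogen such as morpholin-4-yl, or a carboxylic acid at the same place would stay in this range or move beyond the scatter. Equally open, on these data alone, is whether diethylamino would behave the same way on the core of compound 1 or of compound 3, where the group on the aromatic nitrogen differs.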